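The source may report more compounds than this note shows. Statements on the series, on what has been measured and on what is new or still open speak of the compounds shown alone.

Measured so far: compound 1 `CC(C)C[C@H](N)c1cc(C(F)(F)F)ccc1N1CCN(C(=O)CCc2ccccc2O)CC1`, 3300 nM in an assay on HEK293 cells for displacement of a labelled ligand from Melanocortin receptor 4 (Homo sapiens); on this read-out higher numbers stand for weaker inhibition and lower numbers for stronger inhibition; compound 2 `CC(C)C[C@H](N)c1cc(C(F)(F)F)ccc1N1CCN(C(=O)CCc2cccs2)CC1`, 4600 nM.

Compound 1 has the lower of the two numbers, but the step of a 1.4-fold higher number from compound 1 to compound 2 (0.14 log units; within the scatter) lies within the scatter, so the two compounds cannot be ranked. Compound 3 `Cc1[nH]c2ccccc2c1CCC(=O)N1CCN(c2ccc(C(F)(F)F)cc2[C@@H](N)CC(C)C)CC1` differs from compound 1 in one place: 2-methyl-1H-indol-3-yl in place of 2-hydroxyphenyl on a saturated chain carbon, two bonds along the chain from a carbonyl carbon. For the measured compounds named here, only one measured step touches this position, a 1.4-fold higher number from compound 1 to compound 2 (0.14 log units; within the scatter), and it changed little. That step gives no direction for a new aromatic group here, so the expected change is small; a modest gain is estimated, a 2.2-fold lower number from compound 1 to compound 3 (0.34 log units; beyond the scatter). Compound 3 is therefore expected at 1500 nM, between 400 nM and 6000 nM.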

Compound 3, inhibition constant: 1600 nM
The estimate for compound 3 lay 1.1-fold (0.03 log units) below the measured number, within the range that was stated.
By their numbers in this assay, from the lowest: compound 3; then compounds 1 and 2 (each within the scatter of the next).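

This position can move the number beyond the scatter. In this assay, 2-methyl-1H-indol-3-yl, with its two aromatic rings, stands apart from both earlier groups (a 2.1-fold lower number from compound 1 to compound 3 (0.31 log units; beyond the scatter); a 2.9-fold lower number from compound 2 to compound 3 (0.46 log units; beyond the scatter)), whereas 2-hydroxyphenyl and thiophen-2-yl could not be ranked. No data shown here explain this gain.

On these data alone, it remains open whether the methyl group on the indole contributes, which a plain 1H-indol-3-yl group would test. It is also unclear whether a longer chain carrying the same indole would keep the gain.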